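Swapping a cyclopentyl for a cyclopropyl on the thiophene ring

The source may hold more compounds than are shown below. What is called first, only, known or untested is meant among the compounds shown, and "the series" means these compounds.

Of the compounds shown here, three sharing a bicyclic amine core have been measured in an ADME assay on MDCK cells (Canis lupus familiaris) for cytotoxicity, read by microscopy, with a stated time of 48 h; on this read-out lower numbers stand for higher toxicity in this test and higher numbers for lower toxicity in this test. Compound 1 `C[C@H]1[C@H](NCc2cccs2)C[C@H]2C[C@@H]1C2(C)C` gives 25000 nM. Compound 2 `CCCCc1ccsc1CN[C@@H]1C[C@H]2C[C@@H]([C@H]1C)C2(C)C`, carrying a butyl in place of hydrogen on an aromatic carbon, gives 25000 nM, and no change at the digits printed from compound 1 to compound 2 (within the scatter). Compound 3 `C[C@H]1[C@H](NCc2sccc2C2CCCC2)C[C@H]2C[C@@H]1C2(C)C` gives 12500 nM, the lowest of the three numbers, yet a 2.0-fold lower number from compound 1 to compound 3 (0.30 log units; within the scatter) and a 2.0-fold lower number from compound 2 to compound 3 (0.30 log units; within the scatter), so compound 3 is not separated from either neighbour by more than the scatter of this assay.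

Compound 4 `C[C@H]1[C@H](NCc2sccc2C2CC2)C[C@H]2C[C@@H]1C2(C)C` has not yet been measured. It differs from compound 3 in one place: cyclopropyl in place of cyclopentyl on an aromatic carbon.

The two steps that bear on this change are the ones that put the cyclopentyl onto the ring, from hydrogen in compound 1 and from butyl in compound 2; both stayed within the scatter. Since neither adding nor exchanging a substituent at this aromatic carbon has moved the read-out beyond the scatter, the account expects that shrinking the ring to cyclopropyl will also leave the number essentially where it is, with a 2.0-fold higher number from compound 3 to compound 4 (0.30 log units; within the scatter) as the expected step. For compound 4 the estimated value is 25000 nM, with a range from 12500 nM to 50000 nM.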

Compound 4, minimum cytotoxic concentration: 25000 nM
For compound 4 middle estimate and measured number coincide at the digits printed; the range from low to high includes it.
By their numbers in this assay, from the lowest: compounds 3, 1, 2 and 4 (each within the scatter of the next).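

In this assay, the position on the aromatic carbon, two ring bonds from the ring sulfur, now shows no separation for a three-membered ring either: a 2.0-fold higher number from compound 3 to compound 4 (0.30 log units; within the scatter), no change at the digits printed from compound 2 to compound 4 (within the scatter), and no change at the digits printed from compound 1 to compound 4 (within the scatter). The earlier compounds shown here covered only hydrogen, butyl and cyclopentyl here, so compound 4 extends the set to a cyclopropyl with 3 heavy atoms, and exchanging the cyclopentyl with its 5 heavy atoms does not take the read-out beyond the scatter. All four compounds therefore remain unseparated in this test, and nothing available offers an explanation for this lack of separation.

Every substituent shown at this position consists of carbon alone apart from hydrogen itself, so it remains open whether an amine, a carboxylic acid or a hydroxyl group at the same aromatic carbon would give a number beyond the scatter. Also open, from the compounds shown here alone, is whether a phenyl ring or a chain longer than butyl would do so, and whether the same holds with any change to the shared core.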